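The compounds below may be only part of what the source reports. "The series", "measured", "known", "first", "only" and "open" are said of these compounds alone.

Among the compounds with values here, compound 3 `CCCc1ccc(C(=O)Nc2cccc(NC(=O)COc3ccc4c(=O)ccoc4c3)c2)cc1` gives the lowest of the three numbers measured so far in an assay on isolated protein for inhibition of Rho-associated protein kinase 2 (Homo sapiens), read by scintillation counting, radiometric assay and 33P incorporation, with a stated time of 40 min, in the presence of a further agent that is not named here; a lower number here means a stronger inhibitor, a higher number a weaker inhibitor: compound 3 gives 14 nM. Compound 2 `CN(C)c1ccc(C(=O)Nc2cccc(NC(=O)COc3ccc4c(c3)OCCC4=O)c2)cc1` gives 85 nM in this assay, and compound 1 `COc1ccc(OCC(=O)Nc2cccc(NC(=O)c3ccc(N(C)C)cc3)c2)cc1F` gives 652 nM in this assay. Within the data shown here, only one measured pair differs in a single place: a 7.7-fold lower number from compound 1 to compound 2 (0.88 log units; beyond the scatter), a change made on an oxygen on a saturated carbon. Compound 3 differs from compound 2 in two places at once, so those two values can only be set side by side.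

Compound 4 `CCOc1ccc(C(=O)Nc2cccc(NC(=O)COc3ccc4c(=O)ccoc4c3)c2)cc1` is compound 3 with ethoxy in place of propyl on an aromatic carbon. Among the measured compounds shown here, no measured step touches this part of the shared core; the one step measured, a 7.7-fold lower number from compound 1 to compound 2 (0.88 log units; beyond the scatter), was made elsewhere and says nothing about an exchange on the 4-propylphenyl ring. With nothing to point either way, the expected step is a 1.4-fold higher number from compound 3 to compound 4 (0.15 log units; within the scatter), within the usual scatter. Compound 4 is therefore estimated at 20 nM in this assay, with a range from 6 nM to 65 nM.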

Compound 4, half-maximal inhibitory concentration: 9 nM
The estimate for compound 4 lay 2.2-fold (0.35 log units) above the measured number; the measured number falls inside the stated range.
By their numbers in this assay, from the lowest: compounds 4 and 3 (each within the scatter of the next); then compound 2; then compound 1.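

In this assay, the exchange at this place on the aromatic ring gives a 1.6-fold lower number from compound 3 to compound 4 (0.19 log units; within the scatter), so compound 3 and compound 4 cannot be told apart. Within the data shown here, this is the first measured change on this ring: ethoxy has the same count of heavy atoms as propyl but brings an oxygen and a hydrogen-bond acceptor, and neither shifts the number beyond the scatter, so the position accepts this exchange. No measurement here offers an explanation for this result.

Two groups of similar size say little about how much room for change this position has, so a longer chain such as butoxy, or a carboxylic acid, could behave quite differently here. The dimethylamino group of compound 2 also stays unresolved, as that compound differs from compound 3 in two places at once.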